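Urea aryl swap in a pyrazole series against melanoma cells

This account rests on a few compounds, and the source may have more. Where it says the series, first, only, none or still open, it means among the compounds named here.

For the measured compounds named here, the two compounds measured so far share a common core and differ only in the aryl group on the urea. Compound 1 `COc1cc(Cl)cc(-c2nn(-c3cccc(NC(=O)Nc4ccc(Cl)c(C(F)(F)F)c4)c3)cc2-c2ccncc2)c1` carries a 4-chloro-3-(trifluoromethyl)phenyl urea; in a functional assay on Malme-3M cells (Homo sapiens) for inhibition, read by sulforhodamine B assay, with a stated time of 48 h, tested at 1 uM (a lower number here means a stronger effect, a higher number a weaker effect of the compound at the concentration tested), compound 1 gives 67%. Compound 2 `COc1cc(Cl)cc(-c2nn(-c3cccc(NC(=O)Nc4ccc(Cl)c(Cl)c4)c3)cc2-c2ccncc2)c1` carries a 3,4-dichlorophenyl urea, and in this assay compound 2 gives 77%, which is the highest of the two numbers, with compound 1 its nearest neighbour; the step of a number 10 percentage points higher from compound 1 to compound 2 (within the scatter) lies within the scatter, so the two are not distinguished.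

Compound 3 `COc1cc(Cl)cc(-c2nn(-c3cccc(NC(=O)Nc4cccc(C(F)(F)F)c4)c3)cc2-c2ccncc2)c1` is the next member. (3-(trifluoromethyl)phenyl in place of 3,4-dichlorophenyl on an amide-type nitrogen). Going by the values given here, only the step from compound 1 to compound 2 bears on this change, since it also exchanges chloro for trifluoromethyl, and it was within the scatter at a number 10 percentage points higher from compound 1 to compound 2 (within the scatter). Among the compounds with values here, no measured pair tells what the removal of the second chloro does. The author therefore expects no step beyond the scatter in this assay, and the expected step of a number 2 percentage points lower from compound 2 to compound 3 (within the scatter) is small. Compound 3 is estimated at 75% in this assay, within a range of 58% to 92%.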

Compound 3, a percentage reported as activity, at one concentration (the size of the read-out at that concentration, not a potency): 75%
Compound 3: middle estimate and measured number agree at the digits printed; measured number inside the range.
By their numbers in this assay, from the lowest: compounds 1, 3 and 2 (each within the scatter of the next).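

Hydrogen in place of chloro on an aromatic carbon of the urea aryl group is a change that no earlier pair isolated, and in this assay it gives a number 8 percentage points higher from compound 1 to compound 3 (within the scatter), so this chloro can be removed without a difference that can be told from the scatter. The exchange of 3,4-dichlorophenyl for 3-(trifluoromethyl)phenyl on an amide-type nitrogen gives a number 2 percentage points lower from compound 2 to compound 3 (within the scatter), so all three aryl groups on the urea now give numbers that cannot be distinguished, and neither a change of substituent nor the loss of one has yet separated any pair at this position. Nothing shown here bears on why these steps stay so small.

Still open, going by these compounds, is whether any group on this aryl ring moves the number beyond the scatter, for example an amine, a carboxylic acid or a nitrile on that same aromatic carbon, or a plain phenyl carrying neither chloro nor trifluoromethyl. The compounds shown also leave open how the shared core responds to changes away from the urea, since all three differ only in the aryl group on that urea.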